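Notes on cyclopentyl for 3-fluorobenzyl at the ring nitrogen

The source may hold more compounds than are shown below. What is called first, only, known or untested is meant among the compounds shown, and "the series" means these compounds.

Measured so far in an assay on isolated protein for inhibition of protein deacetylase HDAC6 (Homo sapiens), with a stated time of 60 min; on this read-out lower numbers stand for stronger inhibition and higher numbers for weaker inhibition:
- compound 1, `O=C(CCCCCCn1cc(Nc2ncc3ccn(Cc4ccccc4F)c3n2)cn1)NO`, gives 8.4 nM
- compound 2, `O=C(CCCCCn1cc(Nc2ncc3ccn(Cc4cccc(F)c4)c3n2)cn1)NO`, gives 13.7 nM
- compound 3, `O=C(CCCCCCn1cc(Nc2ncc3ccn(Cc4cccc(F)c4)c3n2)cn1)NO`, gives 14.7 nM

Compound 3 sits within the scatter of both other compounds: a 1.8-fold higher number from compound 1 to compound 3 (0.24 log units; within the scatter) and a 1.1-fold higher number from compound 2 to compound 3 (0.03 log units; within the scatter). Neither the position of the fluorine on the benzyl group nor the length of the chain to the hydroxamic acid has moved the read-out beyond the scatter.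

Compound 4, `O=C(CCCCCCn1cc(Nc2ncc3ccn(C4CCCC4)c3n2)cn1)NO`, differs from compound 3 in one place: cyclopentyl in place of 3-fluorobenzyl on an aromatic nitrogen. Within the data shown here, no measured step bears directly on this change; the two measured steps concern the fluorine position and the chain length, and both were within the scatter. Removing the aromatic ring at this nitrogen is therefore untested ground, and the expectation is a modest shift towards a higher number in this assay, with wide uncertainty. The expected step is a 2.0-fold higher number from compound 3 to compound 4 (0.31 log units; beyond the scatter). For compound 4 the estimated value in this assay is 30 nM, with a range from 8 nM to 120 nM.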

Compound 4, half-maximal inhibitory concentration: 22 nM
For compound 4 the middle estimate is 1.4-fold (0.13 log units) above the measured one; low and high end bracket the measured number.
By their numbers in this assay, from the lowest: compounds 1, 2, 3 and 4 (each within the scatter of the next, the first and the last beyond it).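

Cyclopentyl on the aromatic nitrogen stays close to 3-fluorobenzyl in this assay (a 1.5-fold higher number from compound 3 to compound 4 (0.18 log units; within the scatter)), so an aromatic ring at this position is not needed for a number within the scatter of compound 3. Against 2-fluorobenzyl the same kind of replacement goes beyond the scatter, though only modestly (a 2.6-fold higher number from compound 1 to compound 4 (0.42 log units; beyond the scatter)), so the reading of this change depends on which fluorobenzyl group serves as the reference, and this is the first change at this position to pass the scatter. No supporting data are available to explain the result or the difference between these two comparisons.

From the compounds shown here alone, it remains open whether a methyl, a cyclohexyl, an unsubstituted benzyl or a piperidine ring on this nitrogen would keep the number in the same range. Going by these compounds, it is also open whether cyclopentyl would behave the same way on the shorter chain of compound 2.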